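Swapping the Thiophene Ring for Ethylphenyl on a Weak Sulfonamide

A few compounds are considered here, and "the series" means these few. Any claim that something is new, unique, unknown or untested is made for them only; others in the source may bear on it.

The three measured compounds share a core sulfonamide. Within the data shown here, compound 3 `O=S(=O)(Nc1ccc2oc(-c3ccccc3)nc2c1)c1cccs1` carries a thiophen-2-yl group on the sulfonyl sulfur, and in an assay on cells for inhibition of HSP60/HSP10 (Homo sapiens), with a stated time of 60 min (a higher number here means a weaker inhibitor, a lower number a stronger inhibitor), compound 3 gives 90000 nM, the only actual number among the three. Compound 1 `O=S(=O)(Nc1ccc2oc(-c3ccccc3)nc2c1)c1ccccc1Cl` reaches only a limit, > 100000 nM. Compound 2 `COc1ccccc1S(=O)(=O)Nc1ccc2oc(-c3ccccc3)nc2c1` likewise reaches only a limit, > 100000 nM. Accordingly an at least 1.1-fold lower number from compound 1 to compound 3 (0.04 log units; that floor lies within the scatter) and an at least 1.1-fold lower number from compound 2 to compound 3 (0.04 log units; that floor lies within the scatter) are floors, with the limit of > 100000 nM in this assay, at which 2 of the 3 values shown sit, setting the ceiling for both. Compound 4 `CCc1ccc(S(=O)(=O)Nc2ccc3oc(-c4ccccc4)nc3c2)cc1` carries 4-ethylphenyl in place of thiophen-2-yl on a sulfonyl sulfur. Because an at least 1.1-fold lower number from compound 1 to compound 3 (0.04 log units; that floor lies within the scatter) and an at least 1.1-fold lower number from compound 2 to compound 3 (0.04 log units; that floor lies within the scatter) show only the thiophene ring edging beneath the limit, compound 4 is expected to take a step of a 1.3-fold higher number from compound 3 to compound 4 (0.12 log units; within the scatter) and may itself return only a limit. Compound 4 is estimated at 120000 nM, between 40000 nM and 350000 nM.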

Compound 4, half-maximal inhibitory concentration: > 100000 nM
Compound 4 gave a limit, no number; the forecaster's own chance of this, stated with the estimate: 60%; the middle value is on the limit's open side.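

In this assay the value of compound 4 is a limit, not a number, so 4-ethylphenyl on the sulfonyl sulfur gives no sign of a stronger inhibitor than thiophen-2-yl. Among these compounds, the only readable step is an at least 1.1-fold higher number from compound 3 to compound 4 (0.04 log units; that floor lies within the scatter), while the steps linking compound 4 to compound 1 and compound 2 cannot be read. A para-free summary of the series is that nearly all of it now rests at the assay's ceiling: the limit of > 100000 nM in this assay, at which 3 of the 4 values shown sit.

Still open, as far as these compounds go, is whether any group on the sulfonyl sulfur can give a clearly stronger inhibitor. An amine or a carboxylic acid on that ring, or a plain alkyl chain in place of the ring, would be a different kind of test.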